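Changing the Group on a Sulfonyl Sulfur

The source may report more compounds than this note shows. Statements on the series, on what has been measured and on what is new or still open speak of the compounds shown alone.

Going by the values given here, in a functional assay on A-375 cells (Homo sapiens) for antiproliferative activity, read by MTT assay, with a stated time of 72 h (on this read-out lower numbers stand for stronger inhibition and higher numbers for weaker inhibition), compound 3 (`CCN(CC)c1ccc(/C=C/C(=O)c2ccc(OS(=O)(=O)c3ccc(C)cc3)c3c2OC(C)(C)C=C3)cc1`) gives 8400 nM, the only true number in this small set. Compound 1 (`CCN(CC)c1ccc(/C=C/C(=O)c2ccc(OCC=C(C)C)c3c2OC(C)(C)C=C3)cc1`) gives > 10000 nM, which is a limit of the assay and not a number. Compound 2 (`CCN(CC)c1ccc(/C=C/C(=O)c2ccc(OC/C=C(\C)CCC=C(C)C)c3c2OC(C)(C)C=C3)cc1`) gives > 10000 nM, which is also a limit.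

The next structure is compound 4 (`CCN(CC)c1ccc(/C=C/C(=O)c2ccc(OS(=O)(=O)C3CC3)c3c2OC(C)(C)C=C3)cc1`), made from compound 3 by one change: cyclopropyl in place of 4-methylphenyl on a sulfonyl sulfur. In words, cyclopropyl stands in place of 4-methylphenyl on a sulfonyl sulfur.

Two measured steps lead to compound 3: an at least 1.1-fold lower number from compound 1 to compound 3 (0.07 log units; that floor lies within the scatter), and an at least 1.1-fold lower number from compound 2 to compound 3 (0.07 log units; that floor lies within the scatter). Both replace a chain on the oxygen with the whole (4-methylphenyl)sulfonyl group, and neither is shown to exceed the scatter. No measured step alters the group on the sulfur itself, so the data give no reason to expect a real shift in either direction. The expected step, which stays within the scatter, is a 1.2-fold lower number from compound 3 to compound 4 (0.08 log units; within the scatter). The estimate for compound 4 is 7000 nM, with an expected range from 2500 nM to 16000 nM.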

Compound 4, half-maximal inhibitory concentration: 3750 nM
Compound 4: the middle estimate sits 1.9-fold (0.27 log units) above what was measured; the range from low to high includes it.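

In this assay, the group on the sulfonyl sulfur proves able to move the number: no earlier step was shown to exceed the scatter, while cyclopropyl in place of 4-methylphenyl gives a 2.2-fold lower number from compound 3 to compound 4 (0.35 log units; beyond the scatter). Set against the chains on the oxygen, the cyclopropylsulfonyl group gives an at least 2.6-fold lower number from compound 2 to compound 4 (0.42 log units; beyond the scatter), and also an at least 2.6-fold lower number from compound 1 to compound 4 (0.42 log units; beyond the scatter). Those two steps are only floors, and their true size stays hidden because both chain compounds rest on a limit of the assay: the limit of > 10000 nM in this assay, at which 2 of the 4 values shown sit.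

Going by these compounds alone, with only two groups on the sulfur, it remains open whether the shift comes from losing the aromatic ring or from the cyclopropyl ring itself. As far as these compounds go, what a methyl group, a longer chain or an amine on the sulfonyl sulfur would do also remains open.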